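A few compounds are considered here, and "the series" means these few. Any claim that something is new, unique, unknown or untested is made for them only; others in the source may bear on it.

Within the data shown here, compound 2 `N#CC1=C(N)Oc2c(N)cc3nc4ccccc4nc3c2C12C(=O)N(Cc1cnnn1-c1ccccc1Cl)c1ccccc12` is the one member of the pair with a number in a functional assay on HepG2 cells (Homo sapiens) for antiproliferative activity, read by MTT assay, with a stated time of 48 h; on this read-out lower numbers stand for stronger inhibition and higher numbers for weaker inhibition: compound 2 gives 33500 nM. Compound 1 `Cc1ccc(Cl)cc1-n1nncc1CN1C(=O)C2(C(C#N)=C(N)Oc3c2c2nc4ccccc4nc2c2ccccc32)c2ccccc21` reaches only a limit of the assay, giving > 50000 nM. So compound 2 stands as the single measured number of the series, the other value sitting at a limit (the limit of > 50000 nM in this assay, at which 1 of the 2 values shown sits). Compound 3 `CCc1cccc(CC)c1-n1nncc1CN1C(=O)C2(C(C#N)=C(N)Oc3c(N)cc4nc5ccccc5nc4c32)c2ccccc21` carries 2,6-diethylphenyl in place of 2-chlorophenyl on an aromatic nitrogen. Among the measured compounds shown here, no step between measured compounds is available, so no direction is supported by the data; the step of a 1.2-fold higher number from compound 2 to compound 3 (0.08 log units; within the scatter) is expected to stay within the usual scatter. Compound 3 is estimated at 40000 nM in this assay, within 15000 nM to 100000 nM.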

Compound 3, half-maximal inhibitory concentration: 16500 nM
Compound 3: the middle estimate sits 2.4-fold (0.38 log units) above what was measured; the measured number falls inside the stated range.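

The position on the aromatic nitrogen of the five-membered ring now has its first readable step in this assay: 2,6-diethylphenyl in place of 2-chlorophenyl gives a 2.0-fold lower number from compound 2 to compound 3 (0.31 log units; beyond the scatter). This modest step shows that the position accepts a change of aryl group without loss in this assay. Nothing shown gives a cause for the step.

One step cannot separate the loss of chlorine from the entry of the two ethyl groups. Going by these compounds, how a phenyl carrying a single ethyl, a methoxy group or an amine would read at this position remains open.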